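Hydrazone series: aryl replacement at the imine carbon

A few compounds are considered here, and "the series" means these few. Any claim that something is new, unique, unknown or untested is made for them only; others in the source may bear on it.

Measured so far:
- compound 1 `Cn1c(=O)c(=O)n(C2CCCC2)c2nc(N/N=C/c3ccc(F)c(Cl)c3)ncc21`: 9020 nM
- compound 2 `Cn1c(=O)c(=O)n(C2CCCC2)c2nc(N/N=C/c3ccco3)ncc21`: 78700 nM

Both compounds share the core of compound 1 and differ only in the group carried on the carbon with a double bond to nitrogen. In a functional assay on HCT-116 cells (Homo sapiens) for antiproliferative activity, read by MTT assay (a lower number here means a stronger inhibitor, a higher number a weaker inhibitor), compound 1 gives 9020 nM, the lowest of the two numbers; the nearest is compound 2, and the step of an 8.7-fold higher number from compound 1 to compound 2 (0.94 log units; beyond the scatter) places compound 2 clearly weaker.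

The next compound is compound 3 `Cn1c(=O)c(=O)n(C2CCCC2)c2nc(N/N=C/c3ccc(F)cc3F)ncc21`. Relative to compound 1 the change is 2,4-difluorophenyl in place of 3-chloro-4-fluorophenyl on a carbon with a double bond to nitrogen. For the measured compounds named here, only the step from compound 1 to compound 2 bears on this, and it concerns a heteroaromatic replacement rather than a second substituted phenyl, so it is a loose guide at best. Swapping one halogenated phenyl for another is a smaller change than that one, and the expectation is a small to modest weakening, possibly within the scatter, with a drift towards higher numbers because compound 1 anchors at 9020 nM and the only precedent weakens. For compound 3 the expected value in this assay is 15000 nM, with a range of 5000 nM to 45000 nM, corresponding to an estimated step of a 1.7-fold higher number from compound 1 to compound 3 (0.22 log units; within the scatter).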

Compound 3, half-maximal inhibitory concentration: 19800 nM
Compound 3: middle estimate off by 1.3-fold (0.12 log units), on the low side; the range from low to high includes it.
By their numbers in this assay, from the lowest: compound 1; then compound 3; then compound 2.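

In this assay, exchanging one halogenated phenyl for another at the carbon with a double bond to nitrogen gives a 2.2-fold higher number from compound 1 to compound 3 (0.34 log units; beyond the scatter), so this position responds to the halogen pattern on the phenyl ring and not only to replacement of the ring itself. Replacing furan-2-yl with 2,4-difluorophenyl gives a 4.0-fold lower number from compound 2 to compound 3 (0.60 log units; beyond the scatter), and with 3-chloro-4-fluorophenyl also giving a lower number than furan-2-yl, both halogenated phenyl groups here outperform the furan-2-yl group, with no compound shown going against this. No available measurement explains either step.

The step between the two phenyl groups combines the loss of chlorine with a change in the halogen positions, so the compounds shown cannot assign it to either change alone. Also open, going by these compounds, is how this position would respond to an unsubstituted phenyl, a methoxyphenyl or a pyridyl group, any of which would show whether halogens are needed on the ring at all.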